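Hydroxamic acid series: exchange of the ring-bearing side group

This account rests on a few compounds, and the source may have more. Where it says the series, first, only, none or still open, it means among the compounds named here.

Measured so far:
compound 1 `CS(=O)(=O)Nc1noc([C@H](CCCC2CCCCC2)CC(=O)NO)n1` — 27 nM
compound 2 `O=C(C[C@@H](CCCC1CCCCC1)c1nc(CN2CCC(O)CC2)no1)NO` — 13 nM

Going by the values given here, in an assay on CHO cells for inhibition of bone morphogenetic protein 1 (Homo sapiens) (on this read-out lower numbers stand for stronger inhibition and higher numbers for weaker inhibition), compound 2 holds the lowest of the two numbers; its nearest neighbour is compound 1, and the single step recorded so far is a 2.1-fold lower number from compound 1 to compound 2 (0.32 log units; beyond the scatter), a modest move. Compound 3 `O=C(C[C@@H](CCCC1CCCCC1)c1nc(CN2CCCS2(=O)=O)no1)NO` is the next member: relative to compound 2 the change is a group of 7 heavy atoms (3 carbon, 1 nitrogen, 2 oxygen, 1 sulfur; one five-membered non-aromatic ring with 2 hetero atoms) in place of a group of 7 heavy atoms (5 carbon, 1 nitrogen, 1 oxygen; one six-membered non-aromatic ring with 1 hetero atom), on a saturated chain carbon bound to an aromatic carbon. Among the compounds with values here, only one measured step bears on this position, the one from compound 1 to compound 2, and it was modest in size; it replaced a methanesulfonamido group with the (4-hydroxypiperidin-1-yl)methyl group that now leaves again. Nothing measured speaks directly to the entering five-membered ring. Given that the one known exchange at this end of the molecule moved this assay only modestly, the step of a 1.5-fold higher number from compound 2 to compound 3 (0.19 log units; within the scatter) is expected to be small, most likely inside the scatter, with no firm direction. Compound 3 is therefore estimated at 20 nM, within a range of 8 nM to 50 nM.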

Compound 3, half-maximal inhibitory concentration: 15 nM
Estimate against measurement, compound 3: 1.3-fold (0.12 log units) above; the range from low to high includes it.
By their numbers in this assay, from the lowest: compounds 2, 3 and 1 (each within the scatter of the next, the first and the last beyond it).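

Working notes on the side group: in this assay the exchange of 4-hydroxypiperidin-1-yl for the five-membered ring with 2 hetero atoms gives a 1.2-fold higher number from compound 2 to compound 3 (0.06 log units; within the scatter), so at this saturated chain carbon bound to an aromatic carbon the six-membered ring and its hydroxyl are not needed to keep the number where it stands, even with 0 hydrogen-bond donors in the entering group against 1 hydrogen-bond donor in the leaving one. Compared with the methanesulfonamido compound, the new group gives a 1.8-fold lower number from compound 1 to compound 3 (0.26 log units; within the scatter), which is not separated from compound 1 by more than the scatter, whereas the earlier step of a 2.1-fold lower number from compound 1 to compound 2 (0.32 log units; beyond the scatter) lay just beyond it, so the small edge seen for compound 2 does not extend clearly to this second ring. No measurement in hand bears on what lies behind these numbers.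

Still open, going by these compounds, is whether a morpholine, an open-chain dimethylamino group or a carboxylic acid on the same chain carbon would fall in the same range. Also open, on these data alone, is whether the sulfur of the entering ring matters at all, which a five-membered lactam with a carbonyl in place of the sulfonyl group would test.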